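Aryl swap on the aromatic nitrogen: compound 3 to compound 4

A few compounds are considered here, and "the series" means these few. Any claim that something is new, unique, unknown or untested is made for them only; others in the source may bear on it.

Going by the values given here, in a functional assay on HepG2 cells (Homo sapiens) for antiproliferative activity, read by MTT assay, with a stated time of 48 h (on this read-out higher numbers stand for weaker inhibition and lower numbers for stronger inhibition), compound 3 `N#CC1=C(N)Oc2c(c3nc4ccccc4nc3c3ccccc23)C12C(=O)N(Cc1cnnn1-c1cccc(S(N)(=O)=O)c1)c1ccccc12` gives 21500 nM, the only actual number among the three measured compounds. Compound 1 `N#CC1=C(N)Oc2c(c3nc4ccccc4nc3c3ccccc23)C12C(=O)N(Cc1cnnn1-c1ccccc1Br)c1ccccc12` returns only the assay limit, > 50000 nM. Compound 2 `CC(=O)Nc1ccc(-n2nncc2CN2C(=O)C3(C(C#N)=C(N)Oc4c3c3nc5ccccc5nc3c3ccccc43)c3ccccc32)cc1` likewise sits at the assay limit, > 50000 nM. As far as these compounds go, the steps of an at least 2.3-fold lower number from compound 1 to compound 3 (0.36 log units; beyond the scatter) and an at least 2.3-fold lower number from compound 2 to compound 3 (0.36 log units; beyond the scatter) both place compound 3 at a lower number than its partners, and their full size stays unknown because the limit of > 50000 nM in this assay, at which 2 of the 3 values shown sit, caps both starting points. Compound 4 `Cc1ccc(Cl)cc1-n1nncc1CN1C(=O)C2(C(C#N)=C(N)Oc3c2c2nc4ccccc4nc2c2ccccc32)c2ccccc21` carries 5-chloro-2-methylphenyl in place of 3-sulfamoylphenyl on an aromatic nitrogen. Both measured steps ran toward the 3-sulfamoylphenyl, so taking it away in compound 4 is expected to run the other way, as a step of a 2.1-fold higher number from compound 3 to compound 4 (0.32 log units; beyond the scatter) in this assay. For compound 4 the expected value is 45000 nM, within a range from 15000 nM to 150000 nM, and a limit readout is the more probable outcome.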

Compound 4, half-maximal inhibitory concentration: > 50000 nM
Compound 4 ended at the assay's limit (the forecaster's own chance of this, stated with the estimate: 60%); middle value at least 1.1-fold (0.04 log units) from the limit.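

In this assay, going by these compounds alone, 5-chloro-2-methylphenyl in place of 3-sulfamoylphenyl on the aromatic nitrogen gives an at least 2.3-fold higher number from compound 3 to compound 4 (0.36 log units; beyond the scatter), so 3-sulfamoylphenyl remains the only aryl group here with a measured number. This third limit result comes from an aryl group with no hydrogen-bond donor or acceptor, whereas the earlier limit results came from 2-bromophenyl and 4-acetamidophenyl. The steps among compound 1, compound 2 and compound 4 cannot be read: the limit of > 50000 nM in this assay, at which 3 of the 4 values shown sit.

As far as these compounds go, whether a carboxylic acid on the phenyl ring matches the sulfamoyl group remains open. So does the effect of moving the sulfamoyl group to give 4-sulfamoylphenyl.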